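A Longer Alkoxy Chain on a Low-Toxicity Core

The source may report more compounds than this note shows. Statements on the series, on what has been measured and on what is new or still open speak of the compounds shown alone.

Compound 1 `C=CCOc1nc(N)nc2c1ncn2/C=C1/CC1(CO)CO` was tested in an ADME assay on MOLT-3 cells (Homo sapiens) for cytotoxicity, with a stated time of 7 days; a lower number here means that less compound is tolerated, a higher number that more compound is tolerated. In this assay compound 1 gives > 20000 nM, which is a limit of the assay rather than a number. Compound 2 `Nc1nc(OCc2ccccc2)c2ncn(/C=C3/CC3(CO)CO)c2n1` gives > 20000 nM in this assay, also a limit. Compound 3 `Nc1nc(NC2CCCCC2)c2ncn(/C=C3/CC3(CO)CO)c2n1` has "not determined" (no result reported) in this assay. The step that the two limits leave unreadable from compound 1 to compound 2 cannot be sized, as the limit of > 20000 nM in this assay, at which 2 of the 3 values shown sit, shows. Compound 4 `CCCCCCOc1nc(N)nc2c1ncn2/C=C1/CC1(CO)CO` differs from compound 1 by pentyl in place of vinyl on a saturated chain carbon bound to an oxygen on an aromatic ring. For the measured compounds named here, no measured step with a readable size bears on this change, so no step beyond the scatter is anticipated. Compound 4 is expected to give 30000 nM, within 12000 nM to 100000 nM. The expected step that the limit leaves unreadable from compound 1 to compound 4 is thus essentially none, most likely again only a limit.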

Compound 4, half-maximal cytotoxic concentration: > 20000 nM
Compound 4 gave a limit, no number; the forecaster's own chance of this, stated with the estimate: 75%; the middle value lies beyond the limit too.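

Compound 4, like compound 1 and compound 2, gives only a limit and not a number, so no step among these three can be read in this assay: the limit of > 20000 nM in this assay, at which 3 of the 4 values shown sit.

As far as these compounds go, how far apart their true cytotoxic concentrations lie, and whether allyloxy, benzyl-bearing or hexyloxy groups differ at all, stays open.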